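Swapping the Sulfonyl Aryl Group: Compound 2 to Compound 3

This account rests on a few compounds, and the source may have more. Where it says the series, first, only, none or still open, it means among the compounds named here.

Compound 1 `CC1CCN(C2CCN(S(=O)(=O)c3cccc(Br)c3)CC2)CC1` gives 1.2 nM in a functional assay on HT-29 cells (Homo sapiens) for antiproliferative activity, read by CellTiter-Glo, with a stated time of 72 h (a lower number here means a stronger inhibitor, a higher number a weaker inhibitor), and compound 2 `Cc1nc(Cl)sc1S(=O)(=O)N1CCC(N2CCC(C)CC2)CC1` gives 1.5 nM; this is the higher of the two numbers, but the step of a 1.3-fold higher number from compound 1 to compound 2 (0.10 log units; within the scatter) lies within the scatter. Compound 3 `CC1CCN(C2CCN(S(=O)(=O)c3ccc(Cl)c(Cl)c3)CC2)CC1` is not yet measured. It differs from compound 2 by 3,4-dichlorophenyl in place of 2-chloro-4-methyl-1,3-thiazol-5-yl on a sulfonyl sulfur. For the measured compounds named here, the only measured step that bears on this, the exchange of one aryl group for another on the sulfonyl sulfur, moved the number by a 1.3-fold higher number from compound 1 to compound 2 (0.10 log units; within the scatter), so compound 3 is expected to show no shift beyond the scatter, a step of no change at the digits printed from compound 2 to compound 3 (within the scatter). Compound 3 is therefore estimated at 1.5 nM, with a range from 0.5 nM to 5 nM.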

Compound 3, half-maximal inhibitory concentration: 2.2 nM
The estimate for compound 3 lay 1.5-fold (0.17 log units) below the measured number, and the stated range covers the measured number.
By their numbers in this assay, from the lowest: compounds 1, 2 and 3 (each within the scatter of the next).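

In this assay, the exchange on the sulfonyl sulfur gives a step (a 1.5-fold higher number from compound 2 to compound 3 (0.17 log units; within the scatter)) that stays inside the scatter, and so does the comparison with the bromo compound (a 1.8-fold higher number from compound 1 to compound 3 (0.26 log units; within the scatter)). A third aryl group, 3,4-dichlorophenyl, therefore holds this place, and the 2 hydrogen-bond acceptors counted on the leaving 2-chloro-4-methyl-1,3-thiazol-5-yl are not needed for a number in this range. No measurement is available to explain this result. All three groups shown on the sulfonyl sulfur are aromatic rings carrying halogen, so what a methyl group or a ring bearing a carboxylic acid or an amine would do there remains open.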